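This account rests on a few compounds, and the source may have more. Where it says the series, first, only, none or still open, it means among the compounds named here.

Three compounds have been measured in an assay on HeLa cells for agonist activity at Bile acid receptor (Homo sapiens), read by a luciferase reporter, with a stated time of 24 h; a lower number here means that less compound is needed, a higher number that more compound is needed for the effect:
compound 1 `CS(=O)(=O)Nc1ccc(CNC(=O)c2ccc(C34CC(C3)C4)cc2)c(Cl)c1` gives 560 nM;
compound 2 `CS(=O)(=O)Nc1ccc(CNC(=O)c2ccc(OC(F)(F)F)cc2)c(Cl)c1` gives 1090 nM;
compound 3 `CCOc1ccc(C(=O)NCc2ccc(NS(C)(=O)=O)cc2Cl)cc1` gives 2200 nM.

Compound 3 is separated from compound 1 by a 3.9-fold higher number from compound 1 to compound 3 (0.59 log units; beyond the scatter), a gap beyond the scatter, while its distance from compound 2 is a 2.0-fold higher number from compound 2 to compound 3 (0.30 log units; within the scatter), which lies within the scatter; so compound 3 and compound 2 cannot be told apart on these numbers, and only compound 1 clearly needs less material.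

Compound 4 `CC(C)Oc1ccc(C(=O)NCc2ccc(NS(C)(=O)=O)cc2Cl)cc1` differs from compound 3 by methyl in place of hydrogen on a saturated chain carbon bound to an oxygen on an aromatic ring and a saturated chain carbon. Within the data shown here, no measured step makes this exact change. The closest are the two that alter the group on the oxygen of the shared core: swapping trifluoromethyl for ethyl gave a 2.0-fold higher number from compound 2 to compound 3 (0.30 log units; within the scatter), and replacing the bicyclic carbon group with ethoxy gave a 3.9-fold higher number from compound 1 to compound 3 (0.59 log units; beyond the scatter). Adding one carbon to an already small chain is a lesser change than either, so the step in this assay is expected to stay within the scatter, with no clear direction; the estimate for compound 4 is 2000 nM, ranging from 800 nM to 5000 nM, which means an expected step of a 1.1-fold lower number from compound 3 to compound 4 (0.04 log units; within the scatter).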

Compound 4, half-maximal effective concentration: 400 nM
Beside the measured number, compound 4's estimate is 5.0-fold (0.70 log units) above it; the whole stated range lies above it.
By their numbers in this assay, from the lowest: compounds 4, 1, 2 and 3 (each within the scatter of the next, the first and the last beyond it).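

Adding one methyl, which turns ethoxy into isopropoxy, gives a 5.5-fold lower number from compound 3 to compound 4 (0.74 log units; beyond the scatter) in this assay, so at this place a change of a single carbon can produce a step beyond the scatter, which no earlier step of comparable size had shown. Isopropyl also stands clear of trifluoromethyl on the same oxygen, with a 2.7-fold lower number from compound 2 to compound 4 (0.44 log units; beyond the scatter), whereas a 1.4-fold lower number from compound 1 to compound 4 (0.15 log units; within the scatter) leaves compound 4 and the bicyclic carbon group of compound 1 indistinguishable. Nothing at hand explains why one methyl changes the number this much.

As far as these compounds go, whether the trend continues with more branching on this carbon remains open: a tert-butyl group on the oxygen would test that, and a cyclopropyl group or a longer chain such as n-propyl would show whether branching itself matters. It is also unknown whether the isopropoxy step would hold if the chlorine on the shared core were replaced by fluorine.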